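This account rests on a few compounds, and the source may have more. Where it says the series, first, only, none or still open, it means among the compounds named here.

Three compounds have numbers in a functional assay on NCI-H1975 cells (Homo sapiens) for antiproliferative activity, read by CCK-8 assay, with a stated time of 72 h; on this read-out lower numbers stand for stronger inhibition of growth and higher numbers for weaker inhibition of growth. Compound 1 `CCC1C(=O)N(C)c2cnc(-n3ccc4cc(C(=O)NC)ccc43)nc2N1c1ccn(C)n1` gives 35700 nM and compound 2 `CCCNS(=O)(=O)c1ccc(Nc2ncc3c(n2)N(c2ccn(C)n2)C(CC)C(=O)N3C)cc1` gives 21700 nM, two values within the scatter of each other. Compound 3 `CCCNS(=O)(=O)c1ccc(Nc2ncc3c(n2)N(C2CCCC2)[C@H](CC)C(=O)N3C)cc1` gives 2100 nM, lower than compound 1 by more than the scatter, so compound 1 stands with compound 2 at the weak end of this small set.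

Compound 4 `CCCNC(=O)c1ccc2c(ccn2-c2ncc3c(n2)N(c2ccn(C)n2)C(CC)C(=O)N3C)c1` has not yet been measured in this assay. It keeps the core of compound 1 and alters only the amide side chain: ethyl in place of hydrogen on a saturated chain carbon bound to an amide-type nitrogen. This places ethyl in place of hydrogen on a saturated chain carbon bound to an amide-type nitrogen, turning methylcarbamoyl into propylcarbamoyl.

Among the compounds with values here, no two measured compounds differ in a single place, so the size of such a change has not been seen directly. Compound 2 also carries a propylamino group, and its 21700 nM lies within the scatter of compound 1, so no step beyond the scatter is expected. Compound 3 carries that group too and gives a lower number, but it also differs from compound 1 elsewhere. The expected change is a 1.5-fold lower number from compound 1 to compound 4 (0.17 log units; within the scatter), a small drop that should stay within the scatter. For compound 4 the estimated value is 24000 nM, with an expected range from 9000 nM to 60000 nM.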

Compound 4, concentration for 50% growth inhibition: 11000 nM
For compound 4 the middle estimate is 2.2-fold (0.34 log units) above the measured one; measured number inside the range.
By their numbers in this assay, from the lowest: compound 3; then compounds 4, 2 and 1 (each within the scatter of the next, the first and the last beyond it).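

In this assay, within the data shown here, the change from methylcarbamoyl to propylcarbamoyl gives the first direct reading of a single alteration in this set, with a 3.2-fold lower number from compound 1 to compound 4 (0.51 log units; beyond the scatter), a modest step but one beyond the scatter. Among these compounds, it shows that this amide side chain is not indifferent to its length: ethyl in place of hydrogen on a saturated chain carbon bound to an amide-type nitrogen moves the number towards stronger inhibition of growth, on the core of compound 1, something the earlier compounds could not show, as none of them differed from another in one place only. Nothing available here accounts for the size or the direction of this step.

What the compounds shown leave open is whether the trend continues or reverses with a butyl or longer chain on the amide nitrogen, and whether an ethyl chain would fall part-way along the step, or a terminal amine or carboxylic acid on the chain would keep it. This one pair also leaves open whether the same change would give a similar step on any other core.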